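The source may report more compounds than this note shows. Statements on the series, on what has been measured and on what is new or still open speak of the compounds shown alone.

Measured so far:
compound 1 `COc1cc(-c2cc(/C=C/C(=O)c3ccc(N)cc3)[nH]n2)cc(OC)c1OC` — 83%
compound 2 `COc1ccc(-c2cc(/C=C/C(=O)c3ccc(OC)c(OC)c3)[nH]n2)cc1` — 90%

In a functional assay on MDA-MB-468 cells (Homo sapiens) for cytotoxicity, read by sulforhodamine B assay, with a stated time of 48 h, tested at 0.1 uM (a higher number here means a weaker effect of the compound at the concentration tested, a lower number a stronger effect), compound 1 gives 83% and compound 2 gives 90%. Compound 1 has the lower of the two numbers, but the gap to compound 2 lies within the usual scatter, so the two values show no real difference and both point to weak effects at the concentration used. Within the data shown here, no single-change step between measured compounds is available.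

The next compound is compound 3 `COc1cc(-c2cc(/C=C/C(=O)c3ccc(Cl)c(Cl)c3)[nH]n2)cc(OC)c1OC`. It keeps the shared core of compound 1 and differs in one place: 3,4-dichlorophenyl in place of 4-aminophenyl on a carbonyl carbon. Among the measured compounds shown here, with no measured step to lean on, the expectation is a small step from compound 1 to compound 3, a number 1 percentage points higher from compound 1 to compound 3 (within the scatter), in no clear direction and not beyond the scatter. In this assay compound 3 is expected at about 84%, with a likely range from 68% to 100%.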

Compound 3, a percentage reported as activity, at one concentration (the size of the read-out at that concentration, not a potency): 91%
For compound 3 the middle estimate is 7 percentage points below the measured one, within the range that was stated.
By their numbers in this assay, from the lowest: compounds 1, 2 and 3 (each within the scatter of the next).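

Among these compounds, the step of a number 8 percentage points higher from compound 1 to compound 3 (within the scatter) in this assay is the first single-place comparison, and it concerns the group on a carbonyl carbon. Replacing 4-aminophenyl, with its hydrogen-bond donor and acceptor, by 3,4-dichlorophenyl, with neither, therefore gives no measurable separation at the concentration tested, so this one change does not show the position to be sensitive. No measured evidence bears on this result.

Going by these compounds, whether a carboxylic acid, a morpholine or a longer alkyl chain at this same place would separate from 4-aminophenyl remains open. Also open, on these data alone, is whether compound 1 and compound 3 would separate at other concentrations, as this read-out comes from a single concentration and gives no potency.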